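The source may report more compounds than this note shows. Statements on the series, on what has been measured and on what is new or still open speak of the compounds shown alone.

Compound 1 `Cn1cc(C(=O)c2ccc(F)cc2)cc1/C=C/C(=O)NO`: 84%
Compound 2 `Cn1cc(C(=O)c2ccccc2)cc1/C=C/C(=O)NO`: 86%

In an assay on isolated protein for inhibition of histone deacetylase HD2 (Zea mays), tested at 30 uM (on this read-out lower numbers stand for less inhibition and higher numbers for more inhibition at the one concentration tested (going by the name of the read-out)), compound 2 gives 86%, while compound 1 gives 84%; the two values sit within the scatter of each other, the step of a number 2 percentage points higher from compound 1 to compound 2 (within the scatter) being the only measured one. Compound 3 `CN(C)c1ccc(C(=O)c2cc(/C=C/C(=O)NO)n(C)c2)cc1` differs from compound 2 by dimethylamino in place of hydrogen on an aromatic carbon. The measured step concerned a different exchange on the same ring and was within the scatter, so no directional guide exists for this change. The step expected is a number 1 percentage points lower from compound 2 to compound 3 (within the scatter), within the scatter. Compound 3 is therefore estimated at 85%, with a range from 70% to 93%.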

Compound 3, a percentage reported as inhibition, at one concentration (the size of the read-out at that concentration, not a potency): 88%
Compound 3: middle estimate off by 3 percentage points, on the low side, within the range that was stated.
By their numbers in this assay, from the lowest: compounds 1, 2 and 3 (each within the scatter of the next).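

Dimethylamino, with its 3 heavy atoms, is a much larger replacement at this position para to a large group than fluoro, yet hydrogen to dimethylamino gives a number 2 percentage points higher from compound 2 to compound 3 (within the scatter) in this assay. Exchanging fluoro for dimethylamino gives a number 4 percentage points higher from compound 1 to compound 3 (within the scatter), so all three groups compared here read alike at this position. No available measurement accounts for how close these numbers lie.

The compounds shown leave open whether a carboxylic acid or a longer chain at this position would move the number beyond the scatter.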